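Chloro in place of 4-methylphenoxy: note on the series

The compounds below may be only part of what the source reports. "The series", "measured", "known", "first", "only" and "open" are said of these compounds alone.

Compound 1 `CCc1nnsc1CO/N=C/c1c(C)nn(C)c1Oc1ccc(C)cc1` is the reference point. In a functional assay on Huh-7 cells (Homo sapiens) for inhibition, read by MTT assay, with a stated time of 48 h (on this read-out lower numbers stand for stronger inhibition and higher numbers for weaker inhibition), compound 1 gives only a limit of the assay, > 50000 nM. Compound 2 `CCc1nnsc1CO/N=C/c1c(C)nn(C)c1Oc1ccc(OC(F)(F)F)cc1` likewise gives only a limit in this assay, > 50000 nM. For the measured compounds named here, the one recorded step, a step that the two limits leave unreadable from compound 1 to compound 2, is therefore unreadable, since both values sit at the limit of > 50000 nM in this assay, at which 2 of the 2 values shown sit. Compound 1 thus stands at the limit and nowhere else among the numbers shown; no compound measured so far yields a numeric value in this assay.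

Compound 3 `CCc1nnsc1CO/N=C/c1c(C)nn(C)c1Cl` differs from compound 1 in one place: chloro in place of 4-methylphenoxy on an aromatic carbon. Going by the values given here, no measured step touches this change; the only step recorded, from compound 1 to compound 2, concerns a different site and could not be read. The expectation for compound 3 in this assay therefore rests on the standing of compound 1 alone, which is a limit. Compound 3 is expected to remain at that limit, an estimated step that the limit leaves unreadable from compound 1 to compound 3 without readable size. The estimate for compound 3 in this assay is 60000 nM, with a range of 20000 nM to 150000 nM.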

Compound 3, half-maximal inhibitory concentration: > 50000 nM
Compound 3 gave a limit, no number; the forecaster's own chance of this, stated with the estimate: 80%; the middle value is on the limit's open side.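

Compound 3, like compound 1, gives only a limit in this assay, so no new step can be read between compound 1 and compound 3: the limit of > 50000 nM in this assay, at which 3 of the 3 values shown sit.

The compounds shown leave open how chloro and 4-methylphenoxy compare on that aromatic carbon, and whether any change to the shared core gives a numeric value in this assay.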